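This account rests on a few compounds, and the source may have more. Where it says the series, first, only, none or still open, it means among the compounds named here.

Working notes on the cinnamate ester series.

Three compounds have been run in a functional assay on the whole organism (strain Kunming) with Mus musculus as the target, with a stated time of 0.5 h, at a dose of 300 mg/kg by the intraperitoneal route (on this read-out lower numbers stand for a stronger effect and higher numbers for a weaker effect at the one dose given), so far. Compound 1 `COc1cc(OC)c(OC)cc1/C=C/COC(=O)/C=C/c1ccc(OC)c(OC)c1OC` gives 100% in this assay. Compound 2 `COc1ccccc1/C=C/C(=O)OC/C=C/c1cc(OC)c(OC)cc1OC` gives 100% in this assay. Compound 3 `COc1cc(OC)c(OC)cc1/C=C/COC(=O)/C=C/c1c(OC)ccc(OC)c1OC` gives 100% in this assay. For the measured compounds named here, on these numbers compound 2 stands level with compounds 1 and 3 at the digits reported; none of the three differs from another at this dose, so no structural step among them can yet be read against a change in the read-out.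

The next compound to be run is compound 4 `COc1cc(OC)c(OC)cc1/C=C/COC(=O)/C=C/c1ccc(Br)cc1`. It differs from compound 2 by one change: 4-bromophenyl in place of 2-methoxyphenyl on a double-bonded chain carbon bound to a double-bonded chain carbon. Going by the values given here, nothing among the measured compounds tells how such a change moves the read-out in this assay, and the three measured values leave the read-out at its ceiling, so any step from compound 2 to compound 4 can only be flat or downward. The expectation is that the step from compound 2 to compound 4 is close to none beyond the scatter, a number 5 percentage points lower from compound 2 to compound 4 (within the scatter). Compound 4 is therefore estimated at 95% in this assay, with a range from 70% to 100%.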

Compound 4, a percentage reported as activity, at one dose (the size of the read-out at that dose, not a potency): 100%
Compound 4: middle estimate off by 5 percentage points, on the low side; the measured number falls inside the stated range.
By their numbers in this assay, from the lowest: compounds 1, 2, 3 and 4 (each within the scatter of the next).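

For the compounds shown here, the first readable step comes at a double-bonded chain carbon bound to a double-bonded chain carbon: in this assay, 4-bromophenyl in place of 2-methoxyphenyl gives no change at the digits printed from compound 2 to compound 4 (within the scatter). At this dose, therefore, the read-out does not separate the two groups, even though the entering group has bromine and 0 hydrogen-bond acceptors, whereas the leaving group has oxygen and 1 hydrogen-bond acceptor. No independent measurement bears on this result.

On these data alone, whether a group of another kind at this place, such as an amine or a carboxylic acid, would shift the read-out remains open. Also open, as far as these compounds go, is whether the two groups would still match at another dose, since this single-dose read-out gives no potency.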